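A Phenyl Exchange in a Series at Its Limit

The source may report more compounds than this note shows. Statements on the series, on what has been measured and on what is new or still open speak of the compounds shown alone.

In a functional assay on L5178Y cells (Mus musculus) for inhibition, read by MTT assay, with a stated time of 24 h (a higher number here means a weaker inhibitor, a lower number a stronger inhibitor), compound 1 `COc1cc(O)c2c(c1)O[C@H](c1ccc(O)cc1)C/C2=N\Nc1ccccc1` gives >= 11300 nM as a limit of the assay and not a number. Compound 2 `COc1cc(O)c2c(c1)O[C@H](c1ccc(O)cc1)C/C2=N\NC(=O)c1ccc(N)cc1` gives >= 11300 nM as a limit too. Compound 3 `COc1ccc([C@@H]2C/C(=N\Nc3ccccc3)c3c(O)cc(OC)cc3O2)cc1` likewise gives >= 11300 nM as a limit and so has no number of its own. For the measured compounds named here, what the series offers so far is the limit of >= 11300 nM in this assay, at which 3 of the 3 values shown sit, and no compound has yet yielded a number.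

The next step leads to compound 4 `COc1ccc([C@@H]2C/C(=N\NC(=O)c3ccc(N)cc3)c3c(O)cc(OC)cc3O2)cc1` in which (4-aminophenyl)carbonyl takes the place of phenyl on an amine nitrogen (4-aminophenyl)carbonyl in place of phenyl on an amine nitrogen while the rest of the structure stays the same.

Going by the values given here, two measured steps bear on this change. The same exchange appears as a step that the two limits leave unreadable from compound 1 to compound 2 and is the closest guide, although it offers no readable size. The methyl in place of hydrogen on an oxygen on an aromatic ring appears as a step that the two limits leave unreadable from compound 1 to compound 3 and likewise has no readable size. Resting on a step that the two limits leave unreadable from compound 1 to compound 2 as the only precedent, the estimated step that the limit leaves unreadable from compound 3 to compound 4 is expected to stay within the scatter, in neither direction.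

Compound 4 is expected at 14000 nM with an estimated range from 6000 nM to 30000 nM in this assay and may well come out as a limit again.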

Compound 4, half-maximal inhibitory concentration: 3900 nM
The estimate for compound 4 lay 3.6-fold (0.56 log units) above the measured number, and the stated range ends above it.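

In this assay, for the compounds shown here, compound 4 is the first compound of the series to give a number rather than a limit, and it alone carries both the (4-aminophenyl)carbonyl group and the methyl on the oxygen. With the methyl in place, the exchange of phenyl for (4-aminophenyl)carbonyl on the amine nitrogen now has a size, an at least 2.8-fold lower number from compound 3 to compound 4 (0.46 log units; beyond the scatter), and with the (4-aminophenyl)carbonyl group in place, the methyl in place of hydrogen gives an at least 2.8-fold lower number from compound 2 to compound 4 (0.46 log units; beyond the scatter); both sizes are lower bounds, as each starts from a limit. The steps that start from compound 1 cannot be read, so neither change can be sized without the other, and the remaining compounds give no number: the limit of >= 11300 nM in this assay, at which 3 of the 4 values shown sit.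

The compounds shown do not separate the share of the carbonyl from that of the amine in this group, so a plain benzoyl group, or a carboxylic acid in place of the amine, would be needed to tell them apart. On these data alone, whether a longer chain than methyl on that oxygen would carry the same step also stays open.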